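The compounds below may be only part of what the source reports. "The series", "measured", "known", "first", "only" and "open" are said of these compounds alone.

Three compounds in the series carry numbers in a functional assay on DU-145 cells (Homo sapiens) for cytotoxicity, read by trypan blue exclusion, with a stated time of 96 h; on this read-out higher numbers stand for weaker inhibition and lower numbers for stronger inhibition. Compound 2 `COc1cc(OC)c(/C=C/S(=O)(=O)Cc2ccc(Cl)c(N)c2)c(OC)c1` gives 10 nM. Compound 1 `COc1cc(OC)c(/C=C/S(=O)(=O)Cc2ccc(Br)c(N)c2)c(OC)c1` gives 750 nM. Compound 3 `COc1cc(OC)c(/C=C/S(=O)(=O)Cc2ccc(OC)c(NC(C(=O)O)c3ccc(Cl)cc3)c2)c(OC)c1` gives 400 nM. Compound 4 `COc1cc(OC)c(/C=C/S(=O)(=O)Cc2ccc(OC)c(NC(C(=O)O)c3ccc(Br)cc3)c2)c(OC)c1` has not been measured in this assay.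

From compound 2 to compound 1 the change is bromo in place of chloro on an aromatic carbon and the step is a 75-fold higher number from compound 2 to compound 1 (1.88 log units; beyond the scatter). Compound 3 and compound 4 differ by bromo in place of chloro on an aromatic carbon, the same kind of change, not the same one: in compound 1 the bromo sits ortho to an amino group (1 heavy atom) and para to a large group, while in compound 4 it sits para to a large group only. The difference between the core of compound 3 and the core of compound 2 is not broken down here; compound 3 gives a higher number than compound 2, and compound 3 and compound 1 lie within the scatter of each other.

For compound 4 the expected value is 800 nM, with a likely range from 300 nM to 3000 nM. The expected step is a 2.0-fold higher number from compound 3 to compound 4 (0.30 log units; within the scatter). A smaller step than the precedent is estimated because a 75-fold higher number from compound 2 to compound 1 (1.88 log units; beyond the scatter) was measured with the halogen ortho to an amino group, a surrounding that compound 4 lacks.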

Compound 4, half-maximal inhibitory concentration: 300 nM
Compound 4: middle estimate off by 2.7-fold (0.43 log units), on the high side; low and high end bracket the measured number.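

In this assay, bromo in place of chloro on the core of compound 3 gives a 1.3-fold lower number from compound 3 to compound 4 (0.12 log units; within the scatter), so on this core the halogen change leaves the number within the scatter. The change does not carry over in size between the two cores, and the large step seen on the core of compound 2 cannot be assumed on the core of compound 3: the same change on two cores in this assay, a 75-fold higher number (1.88 log units; beyond the scatter) from compound 2 to compound 1 and a 1.3-fold lower number (0.12 log units; within the scatter) from compound 3 to compound 4, 100-fold (2.00 log units) apart, beyond the scatter of two such steps This does not show which difference between the cores sets the two steps apart, and a single pair on each core gives no rule for the change across the series.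

On these data alone, it remains open whether the small step holds with a methyl ester or a primary amide in place of the carboxy group on the core of compound 3. As far as these compounds go, it also remains open how fluoro or iodo in place of the halogen would read on either core, and so whether the large step on the core of compound 2 is specific to bromo.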